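A few compounds are considered here, and "the series" means these few. Any claim that something is new, unique, unknown or untested is made for them only; others in the source may bear on it.

Compound 1 `CC1=C(C(=O)OC(C)(C)C)C(c2ccsc2)NC(=O)N1`: 15%
Compound 2 `CCCC(=O)C1=C(C)NC(=O)NC1c1ccsc1`: 6%

Of the compounds shown here, two have been measured in an assay on membranes from CHO cells for displacement of a labelled ligand from adenosine receptor A1 (Homo sapiens), read by scintillation counting, with a stated time of 60 min, tested at 1 uM; on this read-out lower numbers stand for less inhibition and higher numbers for more inhibition at the one concentration tested (going by the name of the read-out). Compound 1 gives 15% and compound 2 gives 6%. The two share the same core and differ only in the group on the carbonyl carbon; the step of a number 9 percentage points lower from compound 1 to compound 2 (within the scatter) lies within the scatter, so compound 2 cannot be told apart from compound 1 on these numbers, and both sit at the low end of the read-out.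

Compound 3 `CC1=C(C(=O)CC(C)C)C(c2ccsc2)NC(=O)N1` is not yet measured. It differs from compound 2 by methyl in place of hydrogen on a saturated chain carbon bound to two saturated chain carbons. Going by the values given here, no measured step touches this kind of change; the only step at hand, a number 9 percentage points lower from compound 1 to compound 2 (within the scatter), concerns a different group and was within the scatter. With so little to go on, the expected step of a number 2 percentage points higher from compound 2 to compound 3 (within the scatter) is none beyond the scatter. Compound 3 is therefore estimated at 8%, with a range from -6% to 24%.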

Compound 3, a percentage reported as inhibition, at one concentration (the size of the read-out at that concentration, not a potency): 37%
Beside the measured number, compound 3's estimate is 29 percentage points below it; the measured number lies above the stated range.
By their numbers in this assay, from the lowest: compounds 2 and 1 (each within the scatter of the next); then compound 3.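

Adding one methyl to the chain, which turns propyl into isobutyl, raises the number in this assay well past the usual scatter (a number 31 percentage points higher from compound 2 to compound 3 (beyond the scatter)). Isobutyl also stands clear of tert-butoxy on the carbonyl carbon (a number 22 percentage points higher from compound 1 to compound 3 (beyond the scatter)), so the group held there can change this read-out, which the first pair, lying within the scatter, could not show. Nothing at hand gives a reason for this rise.

The compounds shown leave open whether the number keeps climbing with a longer chain such as pentyl, a ring such as cyclohexyl, or an amine on the carbonyl carbon. Since each number comes from one concentration, they also leave open how potent compound 3 actually is.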